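A few compounds are considered here, and "the series" means these few. Any claim that something is new, unique, unknown or untested is made for them only; others in the source may bear on it.

Measured compounds:
Compound 1, `CCCCCCCCc1cn([C@H]2C[C@H](O)[C@@H](CO)O2)c(=O)[nH]c1=O`, gives 140 ug/mL in a functional assay on Raji cells (Homo sapiens); on this read-out lower numbers stand for stronger inhibition and higher numbers for weaker inhibition.
Compound 2, `CCCCCCc1cn([C@H]2C[C@@H]3OP(=O)(O)OC[C@H]3O2)c(=O)[nH]c1=O`, gives only a limit of > 500 ug/mL in this assay.

For the measured compounds named here, compound 1 stands as the only compound of the two with a number in this assay; the other value shown is a limit rather than a number, and the limit of > 500 ug/mL in this assay, at which 1 of the 2 values shown sits, marks where that limit lies. Compound 3, `CCCCCc1cn([C@H]2C[C@H](O)[C@@H](CO)O2)c(=O)[nH]c1=O`, has not yet been measured. It differs from compound 1 in one place: hydrogen in place of propyl on a saturated chain carbon, five bonds along the chain from an aromatic carbon. The shared core, the sugar part and the hydroxyl groups are unchanged, so the step rests entirely on the shortening of the alkyl chain.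

Going by the values given here, no step between measured compounds is available to scale this change, so the expectation rests on compound 1 alone. The author expects that the step from compound 1 to compound 3 in this assay, a 2.3-fold higher number from compound 1 to compound 3 (0.36 log units; beyond the scatter), runs toward weaker inhibition and somewhat beyond the usual scatter. Compound 3 is therefore estimated at 320 ug/mL, with a likely range from 130 ug/mL to 800 ug/mL.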

Compound 3, concentration for 50% inhibition: 328 ug/mL
Compound 3: the middle estimate sits 1.0-fold (0.01 log units) below what was measured; the measured number falls inside the stated range.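

Replacing propyl by hydrogen on a saturated chain carbon, five bonds along the chain from an aromatic carbon, gives a 2.3-fold higher number from compound 1 to compound 3 (0.37 log units; beyond the scatter) in this assay, a modest move toward weaker inhibition that lies beyond the scatter. Until now compound 1 stood alone with a number, and nothing showed whether the outer part of its chain counted at all. This pair shows that it does, with the longer chain going with the stronger inhibition, though only for these two compounds.

From the compounds shown here alone, whether a still longer chain would lower the number further, whether the change runs evenly with chain length, and whether an amine or a carboxylic acid at the chain end would keep the inhibition all stay open. Nothing shown here gives a cause for this step.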